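Hexyl chain in place of aryl on the exocyclic carbon

The source may hold more compounds than are shown below. What is called first, only, known or untested is meant among the compounds shown, and "the series" means these compounds.

Compound 1 `O=C1CS/C(=N\c2csc(-c3ccc(Cl)cc3)c2)N1` is the bare shared core with no exocyclic arm. In a functional assay on HT-29 cells (Homo sapiens) for cytotoxicity, read by MTT assay, with a stated time of 72 h (on this read-out higher numbers stand for weaker inhibition and lower numbers for stronger inhibition), compound 1 gives 17100 nM. For the measured compounds named here, compound 2 `Cc1ccc(/C=C2\S/C(=N\c3csc(-c4ccc(Cl)cc4)c3)NC2=O)cc1` carries a 4-methylphenyl on the exocyclic double-bonded carbon; in this assay compound 2 gives 6400 nM, the lower of the two numbers measured so far, with compound 1 standing higher by a gap beyond the usual scatter. Compound 3 `CCCCCC/C=C1\S/C(=N\c2csc(-c3ccc(Cl)cc3)c2)NC1=O` differs from compound 2 by hexyl in place of 4-methylphenyl on a double-bonded chain carbon bound to a double-bonded ring carbon. Going by the values given here, no step of this kind has been measured. Among the compounds with values here, the only measured change, from compound 1 at 17100 nM to compound 2 at 6400 nM, coincides with the arrival of the whole aryl-bearing arm; whether a ring-free chain of the same length retains that gain is not known from these two compounds. For compound 3 a moderate rise in the number, that is weaker inhibition, is expected, with the estimated step of a 1.7-fold higher number from compound 2 to compound 3 (0.24 log units; within the scatter) likely beyond the scatter but short of a return to compound 1. Compound 3 is expected at 11000 nM, within a range of 4500 nM to 30000 nM.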

Compound 3, half-maximal inhibitory concentration: 33500 nM
Estimate against measurement, compound 3: 3.0-fold (0.48 log units) below, outside the stated range (above it).
By their numbers in this assay, from the lowest: compound 2; then compounds 1 and 3 (each within the scatter of the next).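

In this assay the arm on the exocyclic carbon proves not to be interchangeable: a 5.2-fold higher number from compound 2 to compound 3 (0.72 log units; beyond the scatter) with hexyl in place of 4-methylphenyl on a double-bonded chain carbon bound to a double-bonded ring carbon. Compound 3 at 33500 nM and compound 1 at 17100 nM lie within the scatter of each other, so in these compounds the hexyl arm cannot be told apart from the bare shared core. The lower number of compound 2 therefore goes with the 4-methylphenyl arm and not with the presence of just any arm at this place, and nothing in hand explains the difference between the two arms.

As far as these compounds go, whether the gain needs an aromatic ring or only a ring remains open: a cyclohexyl on the same carbon would separate those two readings, and a plain phenyl would separate the ring from its methyl. From the compounds shown here alone, with one aryl arm and one chain in hand, it is also open how the number responds to a different group in place of that methyl, such as an amine or a carboxylic acid.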